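Sulfonyl aryl change in a 5-hydroxytryptamine receptor 6 series

The source may hold more compounds than are shown below. What is called first, only, known or untested is meant among the compounds shown, and "the series" means these compounds.

Compound 1 `CN(C)CCn1cc(S(=O)(=O)c2ccccc2)c2cccnc21` gives 25 nM in a functional assay on HeLa cells for agonist activity at 5-hydroxytryptamine receptor 6 (Homo sapiens), read by immunoassay (on this read-out lower numbers stand for an effect already at smaller amounts and higher numbers for an effect only at larger amounts of compound), the lowest of the three measured numbers. Compound 2 `Cc1c(S(=O)(=O)c2ccccc2)c2cccnc2n1CCN(C)C` gives 47 nM, and the step of a 1.9-fold higher number from compound 1 to compound 2 (0.27 log units; within the scatter) lies within the scatter. Compound 3 `NCCn1cc(S(=O)(=O)c2ccc(F)cc2)c2cccnc21` gives 166 nM.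

Compound 4 `CN(C)CCn1cc(S(=O)(=O)c2c(Cl)cccc2Cl)c2cccnc21` differs from compound 1 by 2,6-dichlorophenyl in place of phenyl on a sulfonyl sulfur. Among the compounds with values here, no measured single-point step touches the group on the sulfonyl sulfur: the only such step, from compound 1 to compound 2, sits on an aromatic carbon of the core and is within the scatter, while compound 3 differs from compound 1 in two places at once. The expected step is therefore small, a 1.6-fold higher number from compound 1 to compound 4 (0.20 log units; within the scatter), with wide uncertainty. Compound 4 is estimated at 40 nM, in a range from 10 nM to 200 nM.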

Compound 4, half-maximal effective concentration: 31 nM
Compound 4: middle estimate off by 1.3-fold (0.11 log units), on the high side, and the stated range covers the measured number.
By their numbers in this assay, from the lowest: compounds 1, 4 and 2 (each within the scatter of the next); then compound 3.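

Within the data shown here, the step from phenyl to 2,6-dichlorophenyl is the first single-place change read on the sulfonyl sulfur, and in this assay it gives a 1.2-fold higher number from compound 1 to compound 4 (0.09 log units; within the scatter). At this position, then, the two chlorines leave the number within the scatter of the phenyl parent. Nothing at hand accounts for this result.

Still open, as far as these compounds go, is whether a single chlorine, a methoxy group or a carboxylic acid on this phenyl ring would also stay within the scatter. The fluorophenyl group of compound 3 also remains unresolved apart from the different amine on its chain.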